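Trimming the Amine Substituent on a Shared Core

The source may report more compounds than this note shows. Statements on the series, on what has been measured and on what is new or still open speak of the compounds shown alone.

Compound 2 `N#CC1=C(NCN2CCCCC2)N(c2ccccc2)C(=O)N2CCCCC(N3CCCC3)C12` is one of two compounds tested in a functional assay on the whole organism (strain albino) for inhibition, with Rattus norvegicus as the target, read by paw edema, with a stated time of 1 h, at a dose of 20 mmol/kg by the intraperitoneal route; a lower number here means less inhibition, a higher number more inhibition at the dose given (going by the name of the read-out). In that assay compound 2 gives 29.7%, the smaller of the two numbers shown, but only by an amount within the scatter, since compound 1 `N#CC1=C(/N=C/Nc2ccc([N+](=O)[O-])cc2)N(c2ccccc2)C(=O)N2CCCCC(N3CCCC3)C12` gives 32.1% in the same assay. Among the measured compounds shown here, the single measured step, a number 2.4 percentage points lower from compound 1 to compound 2 (within the scatter), swaps a larger group for a smaller one on the same double-bonded ring carbon and leaves the read-out essentially unchanged. Compound 3 `N#CC1=C(N)N(c2ccccc2)C(=O)N2CCCCC(N3CCCC3)C12` differs from compound 2 as follows: hydrogen in place of (piperidin-1-yl)methyl on an amine nitrogen. For the measured compounds named here, no measured step removes a group from this amine nitrogen, so the one step bears on it only loosely; it shows that a change at this position stayed within the scatter. The step expected here is a number 0.3 percentage points higher from compound 2 to compound 3 (within the scatter), none beyond the scatter. Compound 3 is estimated at 30%, with a range from 18% to 42%.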

Compound 3, a percentage reported as inhibition, in the whole organism at one dose (the size of the read-out at that dose, not a potency): 77.9%
Estimate against measurement, compound 3: 47.9 percentage points below; the whole stated range lies below it.
By their numbers in this assay, from the lowest: compounds 2 and 1 (each within the scatter of the next); then compound 3.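

In this assay, among the compounds shown here, this amine nitrogen proves far more sensitive than the earlier compounds suggested: removing (piperidin-1-yl)methyl gives a number 48.2 percentage points higher from compound 2 to compound 3 (beyond the scatter), and the other route to the plain amino group gives a number 45.8 percentage points higher from compound 1 to compound 3 (beyond the scatter). Two quite different substituents had given values within the scatter of each other, so among these three compounds the large gap separates the two substituted nitrogens from the unsubstituted one, rather than one substituent from another. Nothing shown gives a reason for this jump.

As far as these compounds go, it remains open whether a single methyl or an acetyl group on this nitrogen would keep the higher number or bring it back down. These three compounds also leave open whether any substituent at all lowers the read-out or only groups as large as those in the substituted compounds do.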